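A few compounds are considered here, and "the series" means these few. Any claim that something is new, unique, unknown or untested is made for them only; others in the source may bear on it.

Of the compounds shown here, three have been measured in an in vitro functional assay on HEK285-7 cells for antagonist activity at prostaglandin D2 receptor 2 (Homo sapiens), read by BRET and beta-arrestin recruitment; on this read-out lower numbers stand for smaller maximal responses and higher numbers for larger maximal responses. Compound 1 `N#Cc1ccc(-c2nc(C(c3ccc(F)cc3)c3ccc(F)cc3)sc2CC(=O)O)cc1` gives 30%. Compound 2 `O=C(O)Cc1sc(C(c2ccc(F)cc2)c2ccc(F)cc2)nc1-c1ccnc(F)c1` gives 80%, and compound 3 `O=C(O)Cc1sc(C(c2ccc(F)cc2)c2ccc(F)cc2)nc1-c1ccoc1` gives 80%. Compound 3 thus stands level with compound 2 at the digits shown, the two together forming the highest numbers of the three, while compound 1 lies well below: a number 50 percentage points higher from compound 1 to compound 3 (beyond the scatter), and likewise a number 50 percentage points higher from compound 1 to compound 2 (beyond the scatter). Exchanging the 2-fluoropyridin-4-yl of compound 2 for the furan-3-yl of compound 3 moves nothing: no change at the digits printed from compound 2 to compound 3 (within the scatter).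

Compound 4 `O=C(O)Cc1sc(C(c2ccc(F)cc2)c2ccc(F)cc2)nc1-c1ccnc(N2CCC2)c1` is not yet measured. It differs from compound 3 in one place: 2-(azetidin-1-yl)pyridin-4-yl in place of furan-3-yl on an aromatic carbon. Going by the values given here, the step that bears on this change is the one from compound 2 to compound 3, where a 2-fluoropyridin-4-yl and a furan-3-yl gave the same number within the scatter. Compound 4 again carries a pyridin-4-yl group, now as 2-(azetidin-1-yl)pyridin-4-yl, so no step beyond the scatter is expected in this assay, and the expected step is a number 4 percentage points lower from compound 3 to compound 4 (within the scatter). For compound 4 the estimate is 76%, with an expected range from 55% to 95%.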

Compound 4, largest response reached (reported as efficacy), in percent of the reference or control that the assay uses: 80%
Beside the measured number, compound 4's estimate is 4 percentage points below it; the measured number falls inside the stated range.
By their numbers in this assay, from the lowest: compound 1; then compounds 2, 3 and 4 (each within the scatter of the next).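

In this assay, the aromatic carbon next to the ring nitrogen accepts a much larger group with no change at the digits printed from compound 3 to compound 4 (within the scatter), even though 2-(azetidin-1-yl)pyridin-4-yl brings 10 heavy atoms and a four-membered non-aromatic ring where furan-3-yl has 5 heavy atoms. On the pyridin-4-yl group, azetidin-1-yl in place of fluoro gives no change at the digits printed from compound 2 to compound 4 (within the scatter), so the read-out does not separate these two substituents. With a number 50 percentage points higher from compound 1 to compound 4 (beyond the scatter), compound 1 is the only one of the four set apart, and three different groups in place of 4-cyanophenyl now give the same outcome.

No available data bear on the reason for these results. Open, going by these compounds, is whether the gap to compound 1 belongs to the nitrile or to the phenyl ring, which an unsubstituted phenyl would help to separate, and whether a primary amine or a morpholine on the pyridin-4-yl group would hold the same level.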